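Shortening the Alkenyl Ether: Propenyl to Vinyl

The source may hold more compounds than are shown below. What is called first, only, known or untested is meant among the compounds shown, and "the series" means these compounds.

For the measured compounds named here, compound 2 `C/C=C\Oc1cncc(N2CCCNCC2)c1` gives 2090 nM in a functional assay on HEK293 cells for agonist activity at Neuronal acetylcholine receptor; alpha4/beta2 (Homo sapiens), read by FLIPR and calcium flux (a higher number here means that more compound is needed for the effect, a lower number that less compound is needed), the highest of the two numbers measured so far. Compound 1 `C=COc1cc(N2CCCNCCC2)cnc1Br` gives 240 nM in this assay, a gap that lies beyond the usual scatter. Compound 3 `C=COc1cncc(N2CCCNCC2)c1` differs from compound 2 by vinyl in place of prop-1-en-1-yl on an oxygen on an aromatic ring. Going by the values given here, no measured pair isolates this single change, so the step expected here, a 1.7-fold lower number from compound 2 to compound 3 (0.24 log units; within the scatter), is a modest lowering that may not reach beyond the scatter. Compound 3 is accordingly estimated at 1200 nM, with a range from 400 nM to 3500 nM.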

Compound 3, half-maximal effective concentration: 1100 nM
For compound 3 the middle estimate is 1.1-fold (0.04 log units) above the measured one; measured number inside the range.
By their numbers in this assay, from the lowest: compound 1; then compounds 3 and 2 (each within the scatter of the next).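

Vinyl in place of prop-1-en-1-yl on an oxygen on an aromatic ring gives a 1.9-fold lower number from compound 2 to compound 3 (0.28 log units; within the scatter) in this assay. For the compounds shown here, this is the first pair that isolates this position, and it shows that the two groups cannot be told apart here. No available measurement offers an explanation for this result. Open, going by these compounds, is whether a saturated ethyl group, a longer chain such as butenyl, or a benzyl group on the same oxygen would also stay within the scatter of compound 3. Also open, on these data alone, is whether this change would read the same on the core of compound 1.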